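The compounds below may be only part of what the source reports. "The series", "measured", "known", "first", "only" and "open" are said of these compounds alone.

Measured so far:
compound 1, `CCCSc1nc(Cl)c2c(n1)N(Cc1ccccc1)C(C(=O)O)N2`, 49200 nM in a functional assay on PC-3 cells (Homo sapiens) for antiproliferative activity, read by MTT assay, with a stated time of 72 h; a higher number here means a weaker inhibitor, a lower number a stronger inhibitor;
compound 2, `CCCSc1nc(Cl)c2c(n1)N(Cc1cccs1)C(C(=O)N1CCN(C)CC1)N2`, 5020 nM in this assay.

Among the measured compounds shown here, compound 2 holds the lowest of the two numbers recorded; compound 1 is its only neighbour and stands higher by a margin beyond the scatter. Compound 1 and compound 2 differ in more than one place, so nothing is counted as a single step between them, and only what the two values show is taken from the pair.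

Compound 3, `CCCSc1nc(Cl)c2c(n1)N(CC1CCCCC1)C(C(=O)N1CCN(C)CC1)N2`, is the next member and awaits measurement in this assay. Its change against compound 2 is cyclohexyl in place of thiophen-2-yl on a saturated chain carbon bound to a nitrogen on an aromatic ring in a ring. For the measured compounds named here, no step with this change is recorded among the measured compounds. For compound 3 a small step is expected in this assay, toward a somewhat higher number, as a 1.4-fold higher number from compound 2 to compound 3 (0.14 log units; within the scatter). Compound 3 is therefore estimated at 7000 nM, with a range from 2500 nM to 20000 nM.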

Compound 3, half-maximal inhibitory concentration: 12800 nM
Compound 3: the middle estimate sits 1.8-fold (0.26 log units) below what was measured; low and high end bracket the measured number.
By their numbers in this assay, from the lowest: compound 2; then compound 3; then compound 1.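

The place on a saturated chain carbon bound to a nitrogen on an aromatic ring in a ring now has its first readable step: in this assay, cyclohexyl in place of thiophen-2-yl gives a 2.5-fold higher number from compound 2 to compound 3 (0.41 log units; beyond the scatter). The group at this place therefore does register in the read-out, and of this pair the thiophen-2-yl member, compound 2, holds the lower number. No measurement in hand accounts for the step.

This single pair changes ring size, aromatic character and the sulfur all at once, so the share of each stays unresolved; furan-2-yl or cyclopentyl at the same place would begin to separate them. Also open, going by these compounds, is how an open chain such as hexyl would read there.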